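This account rests on a few compounds, and the source may have more. Where it says the series, first, only, none or still open, it means among the compounds named here.

Measured in a functional assay on A2780 cells (Homo sapiens) for inhibition; on this read-out higher numbers stand for weaker inhibition and lower numbers for stronger inhibition:
- compound 1 `CCNCc1cc(-c2c(C(=O)NCC)noc2-c2cc(C(C)C)c(O)cc2O)on1`: 45 nM
- compound 2 `CCCN(CCC)Cc1cc(-c2c(C(=O)NCC)noc2-c2cc(C(C)C)c(O)cc2O)on1`: "not determined" (no result reported)

Not yet measured:
- compound 3 `CCNC(=O)c1noc(-c2cc(C(C)C)c(O)cc2O)c1-c1cc(C(=O)NC)no1`

Compound 2 has no number in this assay, so it gives no baseline. The structural change is methylcarbamoyl in place of (dipropylamino)methyl on an aromatic carbon, with methylcarbamoyl in place of (dipropylamino)methyl on an aromatic carbon. For the measured compounds named here, no measured step in this assay shows what such a change does. Going by the values given here, the only anchor is compound 1 at 45 nM, and no shift beyond the scatter from that level is expected. Compound 3 is expected at 45 nM, with an estimated range of 14 nM to 150 nM.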

Compound 3, half-maximal inhibitory concentration: 100 nM
Beside the measured number, compound 3's estimate is 2.2-fold (0.35 log units) below it; the measured number falls inside the stated range.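

In this assay, methylcarbamoyl in place of (ethylamino)methyl gives a 2.2-fold higher number from compound 1 to compound 3 (0.35 log units; beyond the scatter), so this position keeps inhibition in the nanomolar range with an amide as well as with a secondary amine, at a modest cost. The step from compound 2 to compound 3 cannot be read, as compound 2 has no number. Nothing available explains the modest loss.

Open, on these data alone, is whether a primary amine or a carboxylic acid at this position would hold the level of compound 1. Also open, as far as these compounds go, is how a longer chain on the amide nitrogen would compare with methylcarbamoyl.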